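Acetyl in place of cyanomethoxy on the fused ring

This account rests on a few compounds, and the source may have more. Where it says the series, first, only, none or still open, it means among the compounds named here.

Among the measured compounds shown here, in an in vitro ADME assay on microsomes from liver (Homo sapiens) for metabolic stability, tested at 5 uM (on this read-out higher numbers stand for a longer-lived compound and lower numbers for a shorter-lived compound), compound 2 `CC(C)CCn1nc(-c2cccs2)c(O)c(C2=NS(=O)(=O)c3cc(OCC#N)ccc3N2)c1=O` gives 0.25 h, the lowest of the two numbers so far yet within the scatter of compound 1 `CC(C)CCn1nc(-c2cccs2)c(O)c(C2=NS(=O)(=O)c3cc(OCC(N)=O)ccc3N2)c1=O`, which gives 0.383 h. For the measured compounds named here, the one step measured, a 1.5-fold lower number from compound 1 to compound 2 (0.19 log units; within the scatter), concerns the same position. Compound 3 `CC(=O)c1ccc2c(c1)S(=O)(=O)N=C(c1c(O)c(-c3cccs3)nn(CCC(C)C)c1=O)N2` differs from compound 2 by acetyl in place of cyanomethoxy on an aromatic carbon. That measured step bears only loosely on this change, and it stayed within the scatter, so no step beyond the scatter is expected. For compound 3 the step is estimated at a 1.2-fold higher number from compound 2 to compound 3 (0.08 log units; within the scatter). Compound 3 is expected to give about 0.3 h, between 0.15 h and 0.6 h.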

Compound 3, half-life: 0.0717 h
The estimate for compound 3 lay 4.2-fold (0.62 log units) above the measured number; measured number below the stated range.
By their numbers in this assay, from the lowest: compound 3; then compounds 2 and 1 (each within the scatter of the next).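

In this assay, this aromatic carbon proved able to shift the half-life beyond the scatter, both with acetyl in place of cyanomethoxy (a 3.5-fold lower number from compound 2 to compound 3 (0.54 log units; beyond the scatter)) and with acetyl in place of carbamoylmethoxy (a 5.3-fold lower number from compound 1 to compound 3 (0.73 log units; beyond the scatter)). Changing only the end of the oxygen-linked chain, cyano in place of carbamoyl, had stayed within the scatter, whereas replacing the whole chain did not. No measurement shown accounts for this shorter half-life. Still open, from the compounds shown here alone, is whether the shift follows the acetyl itself or the loss of the oxygen-linked chain. A methoxy group, an amine or a carboxylic acid on this carbon would bear on that.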